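Thiophen-2-yl on the Saturated Ring Carbon of Compound 1

The source may report more compounds than this note shows. Statements on the series, on what has been measured and on what is new or still open speak of the compounds shown alone.

Compound 1 `COc1ccc(C2C(C#N)=C(N)N(c3ccc(S(N)(=O)=O)cc3)C3=C2C(=O)CCC3)cc1` gives 50% in a functional assay on Ehrlich cells (Mus musculus) for antiproliferative activity, read by trypan blue exclusion, with a stated time of 2 h, tested at 25 ug/mL; a higher number here means a stronger effect of the compound at the concentration tested, a lower number a weaker effect. Compound 2 `N#CC1=C(N)N(c2ccc(S(N)(=O)=O)cc2)C2=C(C(=O)CCC2)C1c1ccc(Cl)cc1Cl` gives 50%, so the two stand together as the highest of three numbers, with no change at the digits printed from compound 1 to compound 2 (within the scatter). Going by the values given here, compound 3 `N#CC1=C(N)N(c2ccc(S(N)(=O)=O)cc2)C2=C(C(=O)CCC2)C1c1ccco1` gives 0%, and the step of a number 50 percentage points lower from compound 1 to compound 3 (beyond the scatter) is the only measured step that bears on the change now considered. Compound 4 `N#CC1=C(N)N(c2ccc(S(N)(=O)=O)cc2)C2=C(C(=O)CCC2)C1c1cccs1` differs from compound 1 in one place: thiophen-2-yl in place of 4-methoxyphenyl on a saturated ring carbon. Thiophen-2-yl is, like furan-2-yl, a five-membered aromatic ring with one hetero atom, so compound 4 may follow compound 3 downward; still, no step from furan-2-yl to thiophen-2-yl is available, and one step is a thin basis. The expected step is a number 30 percentage points lower from compound 1 to compound 4 (beyond the scatter). Compound 4 is estimated at 20%, between 0% and 50%.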

Compound 4, a percentage reported as activity, at one concentration (the size of the read-out at that concentration, not a potency): 80%
The estimate for compound 4 lay 60 percentage points below the measured number, and the stated range ends below it.
By their numbers in this assay, from the lowest: compound 3; then compounds 1 and 2 (each within the scatter of the next); then compound 4.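

Thiophen-2-yl on the saturated ring carbon gives a number 30 percentage points higher from compound 1 to compound 4 (beyond the scatter) and a number 30 percentage points higher from compound 2 to compound 4 (beyond the scatter) in this assay and so shows that a change at this carbon can raise the read-out as well as abolish it. Furan-2-yl and thiophen-2-yl, both five-membered aromatic rings with one hetero atom, are far apart, with a number 80 percentage points higher from compound 3 to compound 4 (beyond the scatter) and so that shared ring size does not settle the outcome here. Nothing available explains this difference. On these data alone, whether thiophen-3-yl, pyridin-2-yl or cyclohexyl at this carbon would match thiophen-2-yl remains open.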